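Shortening the ester chain of compound 2

The source may report more compounds than this note shows. Statements on the series, on what has been measured and on what is new or still open speak of the compounds shown alone.

Compound 1 `Nc1ncnc2c1ncn2CC(O)C(=O)OCCO` in a functional assay on PRK cells (Oryctolagus cuniculus) for cytotoxicity (a higher number here means that more compound is tolerated, a lower number that less compound is tolerated), gives > 400 ug/mL, which is a limit of the assay. Compound 2 `CCCCOC(=O)C(O)Cn1cnc2c(N)ncnc21` gives 200 ug/mL. Compound 3 `CCC(C)OC(=O)C(O)Cn1cnc2c(N)ncnc21` gives > 400 ug/mL, again a limit.

Compound 2 thus holds the only number shown; the other two values are limits, both at the limit of > 400 ug/mL in this assay, at which 2 of the 3 values shown sit. Compound 4 `CCOC(=O)C(O)Cn1cnc2c(N)ncnc21` differs from compound 2 by hydrogen in place of ethyl on a saturated chain carbon, two bonds along the chain from an oxygen next to a carbonyl group. For the measured compounds named here, two measured steps bear on it: an at least 2.0-fold lower number from compound 1 to compound 2 (0.30 log units; that floor lies within the scatter), and an at least 2.0-fold higher number from compound 2 to compound 3 (0.30 log units; that floor lies within the scatter). Both changes at this chain lifted the value to a limit, so a higher number is expected for compound 4, with a 2.0-fold higher number from compound 2 to compound 4 (0.30 log units; within the scatter). Compound 4 is therefore estimated at 400 ug/mL, within 200 ug/mL to 800 ug/mL.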

Compound 4, minimum cytotoxic concentration: > 400 ug/mL
Compound 4: no number, only a limit; the forecaster's own chance of this, stated with the estimate: 60%; the middle value sits exactly at the limit.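

In this assay compound 4, the ethyl ester, gives > 400 ug/mL, which is a limit and not a number. Taking ethyl off the butyl chain gives an at least 2.0-fold higher number from compound 2 to compound 4 (0.30 log units; that floor lies within the scatter), so the straight shorter chain ends up at the same limit as the branched sec-butyl ester of compound 3. Compound 2 remains the only compound with a real number, and the steps among the other compounds cannot be read: the limit of > 400 ug/mL in this assay, at which 3 of the 4 values shown sit.

Going by these compounds, how much compound the ethyl ester truly tolerates stays open. So does whether a hexyl ester or the free carboxylic acid would give a number at all.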